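Diaryl ether variations on a piperidine amide series

The source may hold more compounds than are shown below. What is called first, only, known or untested is meant among the compounds shown, and "the series" means these compounds.

Measured so far:
compound 1 `CC(C)C(=O)Nc1cccc(C2CCN(Cc3cccc(Oc4ccc(Cl)cc4)c3)CC2)c1` gives 2000 nM in a functional assay on HEK293 cells for antagonist activity at melanin-concentrating hormone receptor 1 (Rattus norvegicus), read by FLIPR; a lower number here means a stronger inhibitor, a higher number a weaker inhibitor
compound 2 `CC(C)C(=O)Nc1cccc(C2CCN(Cc3cccc(Oc4cccc(C(F)(F)F)c4)c3)CC2)c1` gives 5400 nM in this assay

Among the compounds with values here, compound 2 holds the highest of the two numbers so far; its nearest neighbour is compound 1, and the only step between measured compounds, a 2.7-fold higher number from compound 1 to compound 2 (0.43 log units; beyond the scatter), separates them. That step swapped the aryl group on the ether oxygen and cost a modest amount of potency.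

Compound 3 `CC(C)C(=O)Nc1cccc(C2CCN(Cc3cccc(Oc4ccc(Cl)c(Cl)c4)c3)CC2)c1` is the next member to be measured. The change from compound 2 is 3,4-dichlorophenyl in place of 3-(trifluoromethyl)phenyl on an oxygen on an aromatic ring. Compared with compound 1, compound 3 keeps the chlorine at the same position and carries a second chlorine on the ring.

Within the data shown here, only the step from compound 1 to compound 2 bears on this change, and it ran in the weakening direction when the 4-chlorophenyl group was replaced. Returning a chlorine-bearing ring is therefore expected to recover roughly that loss, so the step of a 3.6-fold lower number from compound 2 to compound 3 (0.56 log units; beyond the scatter) is estimated to fall in the strengthening direction and to lie beyond the scatter. Among the measured compounds shown here, the added chlorine has no precedent, so the range is kept wide. Compound 3 is estimated at 1500 nM in this assay, between 500 nM and 4500 nM.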

Compound 3, half-maximal inhibitory concentration: 2600 nM
For compound 3 the middle estimate is 1.7-fold (0.24 log units) below the measured one; the range from low to high includes it.
By their numbers in this assay, from the lowest: compounds 1 and 3 (each within the scatter of the next); then compound 2.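

In this assay, the step of a 1.3-fold higher number from compound 1 to compound 3 (0.11 log units; within the scatter) shows that chloro in place of hydrogen on an aromatic carbon of the aryl group on the ether oxygen gives no readable difference in potency. The step of a 2.1-fold lower number from compound 2 to compound 3 (0.32 log units; beyond the scatter) is modest but beyond the scatter, and with the earlier step of a 2.7-fold higher number from compound 1 to compound 2 (0.43 log units; beyond the scatter) it places both chlorine-bearing aryl groups on the stronger side of the 3-(trifluoromethyl)phenyl group, a pattern that holds for these three compounds and that none of them goes against. Nothing on hand speaks to the reason for these differences.

Still open is whether chlorine itself matters at this position, since the compounds shown do not include an unsubstituted phenyl, or a ring carrying a methoxy group or a nitrile, on the ether oxygen. From the compounds shown here alone, all three compounds also share the same core and the same amide, so it remains unknown whether a replacement there, such as a carboxylic acid or an amine in place of the amide, would shift the numbers more than any aryl group variation seen here.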